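The source may hold more compounds than are shown below. What is called first, only, known or untested is meant among the compounds shown, and "the series" means these compounds.

Values measured in a physicochemical assay for solubility, in simulated intestinal fluid (on this read-out lower numbers stand for lower solubility and higher numbers for higher solubility), are these
- Compound 1 `C[C@H](O)c1n[nH]c2c1CN(C1=NC(NCc3c(F)cccc3C(F)(F)F)c3cccc(C(N)=O)c3N1)C2` gives 12 ug/mL
- Compound 2 `C[C@@H](O)c1n[nH]c2c1CN(C1=NC(NCc3c(F)cccc3C(F)(F)F)c3cccc(C(N)=O)c3N1)C2` gives 11 ug/mL
- Compound 3 `NC(=O)c1cccc2c(NCc3c(F)cccc3C(F)(F)F)nc(N3Cc4cn[nH]c4C3)nc12` gives 6 ug/mL

Compound 2 at 11 ug/mL lies within the usual scatter of both compound 1 and compound 3, so it cannot be set apart from either. Compound 4 `C[C@@H]1c2n[nH]cc2CN1C1=NC(NCc2c(F)cccc2C(F)(F)F)c2cccc(C(N)=O)c2N1` has not yet been measured. It differs from compound 2 by one exchange of group, on a carbon with a double bond to nitrogen (a group of 9 heavy atoms (6 carbon, 3 nitrogen; one five-membered non-aromatic ring with 1 hetero atom, one five-membered aromatic ring with 2 hetero atoms) in place of a group of 11 heavy atoms (7 carbon, 3 nitrogen, 1 oxygen; one five-membered non-aromatic ring with 1 hetero atom, one five-membered aromatic ring with 2 hetero atoms), on a carbon with a double bond to nitrogen). Among the measured compounds shown here, the only measured step (a 1.1-fold lower number from compound 1 to compound 2 (0.04 log units; within the scatter)) lies within the scatter. That step alters a stereocentre at a saturated chain carbon and leaves atoms and bonds the same, so it bears only weakly on an exchange of group. For the measured compounds named here, no measured step covers such an exchange. Compound 3 gives 6 ug/mL and so stays within the scatter of compound 2. In this assay the expected step is a 1.2-fold lower number from compound 2 to compound 4 (0.09 log units; within the scatter) and thus none beyond the scatter. Compound 4 is estimated at 9 ug/mL with an expected range of (4 ug/mL to 20 ug/mL).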

Compound 4, solubility: 34 ug/mL
Compound 4: the middle estimate sits 3.8-fold (0.58 log units) below what was measured; measured number outside the range, above it.
By their numbers in this assay, from the lowest: compounds 3, 2 and 1 (each within the scatter of the next); then compound 4.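

In this assay, among the compounds shown here, this place, on a carbon with a double bond to nitrogen, now proves open to change: the only earlier step altered just a stereocentre and stayed within the scatter. Exchanging the group of 11 heavy atoms, which holds the oxygen, for the group of 9 heavy atoms, which holds none, gives a 3.1-fold higher number from compound 2 to compound 4 (0.49 log units; beyond the scatter) and also a 2.8-fold higher number from compound 1 to compound 4 (0.45 log units; beyond the scatter) so the exchange goes beyond the scatter from both starting compounds. These two starting compounds have the same atoms and bonds and lie within the scatter of each other, so the reading holds for either stereocentre configuration in the leaving group.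

Still open, going by these compounds, is whether an amine or a carboxylic acid on the same group would move the number further, or how the opposite configuration of the entering group would compare. Nothing shown here accounts for the rise.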